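A few compounds are considered here, and "the series" means these few. Any claim that something is new, unique, unknown or untested is made for them only; others in the source may bear on it.

Working notes on the series. Among the compounds with values here, in a functional assay (B cells) with Mus musculus as the target (on this read-out lower numbers stand for an effect already at smaller amounts and higher numbers for an effect only at larger amounts of compound), compound 2 `C=CCn1c(=O)n(Cc2ccccc2)c2nc(N)nc(O)c21` gives 5 uM, the lowest of the two numbers so far; compound 1 `Nc1nc(O)c2c(n1)n(C1OC(CO)[C@@H](O)[C@H]1O)c(=O)n2Cc1ccc(Cl)cc1` gives 14 uM in this assay, a gap beyond the usual scatter. Compound 3 `C=CCn1c(=O)n(CCCC)c2nc(N)nc(O)c21` has not been measured in this assay. Compound 3 differs from compound 2 by propyl in place of phenyl on a saturated chain carbon bound to an aromatic nitrogen. Within the data shown here, no step of this kind is available, so the expectation rests on compound 2 alone. A modest rise in the number is expected, with the estimated step of a 2.4-fold higher number from compound 2 to compound 3 (0.38 log units; beyond the scatter) around the edge of the scatter. For compound 3 the estimated value in this assay is 12 uM, with a range from 4 uM to 40 uM.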

Compound 3, concentration for half-maximal effect: 2 uM
Compound 3: the middle estimate sits 6.0-fold (0.78 log units) above what was measured, and the stated range ends above it.
By their numbers in this assay, from the lowest: compound 3; then compound 2; then compound 1.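

Propyl in place of phenyl on a saturated chain carbon bound to an aromatic nitrogen gives a 2.5-fold lower number from compound 2 to compound 3 (0.40 log units; beyond the scatter) in this assay, so the six-membered aromatic ring is not required at this place for an effect on this read-out. An open chain, with butyl replacing benzyl, is tolerated here and carries the lower number. Nothing at hand explains this step.

On these data alone, whether a longer chain such as hexyl would lower the number further remains open. So does the effect of an amine or a carboxylic acid at the chain end.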